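The compounds below may be only part of what the source reports. "The series", "measured", "known", "first", "only" and "open" are said of these compounds alone.

Measured so far in a functional assay on PANC-1 cells (Homo sapiens) for cytotoxicity, read by WST assay, with a stated time of 24 h; on this read-out higher numbers stand for weaker inhibition and lower numbers for stronger inhibition:
- Compound 1 `O=C(CCCCCCCCc1ccccc1)N1CCCCC1`: > 100000 nM, a limit
- Compound 2 `Cc1ccc(CCCCCCCCC(=O)N2CCCCC2)cc1`: > 100000 nM, a limit

Compound 2 stands only at a limit, > 100000 nM. Compound 3 `O=C(CCCCCCCCc1ccc(C(F)(F)F)cc1)N1CCCCC1` differs from it by one change: trifluoromethyl in place of methyl on an aromatic carbon, para to a large group. Among the measured compounds shown here, the only measured step that bears on this, a step that the two limits leave unreadable from compound 1 to compound 2, has no readable size, and the evidence amounts to the limit of > 100000 nM in this assay, at which 2 of the 2 values shown sit. No step beyond the scatter is therefore expected in this assay, and the assay may again report only a limit. The expected step is a number no higher from compound 2 to compound 3 (the limit leaves the size open). The estimated value for compound 3 is 100000 nM, with an expected range of 40000 nM to 250000 nM.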

Compound 3, half-maximal inhibitory concentration: 54000 nM
Compound 3: the middle estimate sits 1.9-fold (0.27 log units) above what was measured; low and high end bracket the measured number.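

In this assay, trifluoromethyl on the aromatic carbon para to a large group gives the only number among these compounds rather than a limit. Replacing methyl gives an at least 1.8-fold lower number from compound 2 to compound 3 (0.26 log units; that floor lies within the scatter), and replacing hydrogen gives an at least 1.8-fold lower number from compound 1 to compound 3 (0.26 log units; that floor lies within the scatter), so neither floor establishes a step beyond the scatter. The limit still governs how far these steps can be read: the limit of > 100000 nM in this assay, at which 2 of the 3 values shown sit.

As far as these compounds go, whether chlorine or a carboxylic acid at this position would change the number remains open. So does the effect of a shorter chain or an amine in place of the piperidine amide.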